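From morpholin-4-yl to cyclopentylamino on the carbonyl carbon

The source may report more compounds than this note shows. Statements on the series, on what has been measured and on what is new or still open speak of the compounds shown alone.

Among the measured compounds shown here, compound 1 `Nc1sc(-c2ccc(Cl)cc2)c(-c2ccc(Cl)cc2)c1C(=O)N1CCOCC1` gives 1870 nM in a functional assay on A549 cells (Homo sapiens) for inhibition, read by sulforhodamine B assay, with a stated time of 72 h (on this read-out lower numbers stand for stronger inhibition and higher numbers for weaker inhibition), the lowest of the two numbers measured so far. For the measured compounds named here, compound 2 `CC(=O)Nc1sc(-c2ccc(Cl)cc2)c(-c2ccc(Cl)cc2)c1C(=O)N1CCCCC1` gives 6010 nM in this assay, a higher number that lies beyond the usual scatter; since the two compounds differ in more than one place, the pair shows only these two values and no single step.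

Compound 3 `Nc1sc(-c2ccc(Cl)cc2)c(-c2ccc(Cl)cc2)c1C(=O)NC1CCCC1` has not yet been measured. It differs from compound 1 in one place: cyclopentylamino in place of morpholin-4-yl on a carbonyl carbon. Going by the values given here, no step between measured compounds that changes only this group is available, so the size of the change has no precedent among the compounds at hand. The step from compound 1 to compound 3 is expected to be small, a 1.3-fold higher number from compound 1 to compound 3 (0.13 log units; within the scatter), with no clear direction beyond the scatter. Compound 3 is therefore expected to give 2500 nM, with a range from 800 nM to 8000 nM.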

Compound 3, half-maximal inhibitory concentration: 6790 nM
Estimate against measurement, compound 3: 2.7-fold (0.43 log units) below; measured number inside the range.
By their numbers in this assay, from the lowest: compound 1; then compounds 2 and 3 (each within the scatter of the next).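

Among the compounds shown here, replacing morpholin-4-yl with cyclopentylamino on the carbonyl carbon gives the first single-place comparison in this assay and weakens inhibition, with a 3.6-fold higher number from compound 1 to compound 3 (0.56 log units; beyond the scatter) and a step that lies beyond the scatter. This position is therefore not indifferent to the group it carries, even though both groups have 6 heavy atoms. The change alters the ring size, removes the ring oxygen and adds the amide hydrogen all at once, and no measurement at hand separates these features or explains the loss.

On these data alone, it remains open whether pyrrolidin-1-yl or piperazin-1-yl on the same carbonyl carbon would stay as close to compound 1 as the morpholin-4-yl parent or fall towards compound 3. Cyclohexylamino or a methyl(cyclopentyl)amino group would leave the same question open for the ring size and the amide hydrogen.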